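The compounds below may be only part of what the source reports. "The series", "measured", "known", "first", "only" and "open" are said of these compounds alone.

Measured so far in a physicochemical assay for solubility, at pH 6.5; a lower number here means a less soluble compound, a higher number a more soluble compound:
- compound 1 `NC(=O)c1ccc(-c2cnc3ccc(-c4cccc(S(=O)(=O)C5CC5)c4)nn23)cc1`; in this assay compound 1 gives < 5000 nM, which is a limit of the assay and not a number.
- compound 2 `CS(=O)(=O)c1ccc(-c2cnc3ccc(-c4cccc(S(=O)(=O)C5CC5)c4)nn23)cn1`; in this assay compound 2 gives < 5000 nM, again a limit of the assay rather than a number.

Among the compounds with values here, compound 2 therefore stands only at a limit in this assay, with no read number of its own; the single further value shown is likewise a limit, so the limit of < 5000 nM in this assay, at which 2 of the 2 values shown sit, is all that the series has established.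

The step under consideration goes from compound 2 to compound 3 `C[S+]([O-])c1ccc(-c2cnc3ccc(-c4cccc(S(=O)(=O)C5CC5)c4)nn23)cc1`. The change is a group of 9 heavy atoms (7 carbon, 1 oxygen, 1 sulfur; one six-membered aromatic ring of carbon only) in place of a group of 10 heavy atoms (6 carbon, 1 nitrogen, 2 oxygen, 1 sulfur; one six-membered aromatic ring with 1 hetero atom), on an aromatic carbon.

Within the data shown here, only one measured step exists for comparison, a step that the two limits leave unreadable from compound 1 to compound 2, and both of its ends are limits, so its size is not readable and it gives no direction for the present change. With both measured compounds sitting at the same limit, no trend beyond the scatter can be claimed for the series.

The step from compound 2 to compound 3 is accordingly expected to be a step that the limit leaves unreadable from compound 2 to compound 3, that is, nothing beyond the scatter. For compound 3 the estimate in this assay is 3000 nM, with a range from 800 nM to 12000 nM, and a limit rather than a number is the more likely report.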

Compound 3, solubility: < 5000 nM
Compound 3 ended at the assay's limit; the forecaster's own chance of this, stated with the estimate: 65%; the middle value lies beyond the limit too.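

In this assay compound 3 gives < 5000 nM, a limit of the assay and not a number. Within the data shown here, no step among compound 1, compound 2 and compound 3 can be read, and the series still rests on one limit: the limit of < 5000 nM in this assay, at which 3 of the 3 values shown sit. The compounds shown leave open where any of the three lies in this assay, and whether either change alters the read-out.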